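A few compounds are considered here, and "the series" means these few. Any claim that something is new, unique, unknown or untested is made for them only; others in the source may bear on it.

compound 1 `COc1cc(C(=O)c2cn(-c3ccccc3Cl)cc2-c2ccccc2)cc(OC)c1OC` gives 1800 nM
compound 2 `COc1ccccc1-n1cc(C(=O)c2cc(OC)c(OC)c(OC)c2)c(-c2ccccc2)c1` gives 150 nM

Compound 2 stands lowest at 150 nM in a functional assay on MCF7 cells (Homo sapiens) for cytotoxicity, read by MTT assay, with a stated time of 96 h (on this read-out lower numbers stand for stronger inhibition and higher numbers for weaker inhibition), so far. Among the compounds with values here, the change to compound 3 `COc1cc(C(=O)c2cn(-c3cccc(Br)c3)cc2-c2ccccc2)cc(OC)c1OC` is this: 3-bromophenyl in place of 2-methoxyphenyl on an aromatic nitrogen and no measured compound carries 3-bromophenyl. Within the data shown here, the one measured step, a 12-fold lower number from compound 1 to compound 2 (1.08 log units; beyond the scatter) with methoxy in place of chloro on an aromatic carbon, was large. Among the measured compounds shown here, compound 3 also lacks that methoxy, so a higher number is expected in this assay and, with only one step to go on, the expectation is loose. For compound 3 the expected step is a 3.3-fold higher number from compound 2 to compound 3 (0.52 log units; beyond the scatter) and it would mean weaker inhibition. Compound 3 is estimated at 500 nM with 100 nM to 2500 nM as the expected range.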

Compound 3, half-maximal inhibitory concentration: 78 nM
Beside the measured number, compound 3's estimate is 6.4-fold (0.81 log units) above it, outside the stated range (below it).
By their numbers in this assay, from the lowest: compounds 3 and 2 (each within the scatter of the next); then compound 1.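

With 3-bromophenyl in place of 2-methoxyphenyl on the aromatic nitrogen, the data show a 1.9-fold lower number from compound 2 to compound 3 (0.28 log units; within the scatter) and so no clear change, which means the methoxy is not required for a low number here. A halogen on this ring does not by itself bring a high number either: 3-bromophenyl in place of 2-chlorophenyl gives a 23-fold lower number from compound 1 to compound 3 (1.36 log units; beyond the scatter) and thus a large gain. No measurement here explains these differences. That last step changes both the halogen and its place, and the compounds shown cannot separate the two. As far as these compounds go, how a plain phenyl or an aminophenyl would compare on this nitrogen also stays open.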